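Shortening the Side-Chain Acid on a Shared Core

The compounds below may be only part of what the source reports. "The series", "measured", "known", "first", "only" and "open" are said of these compounds alone.

Compound 1 `N=C(N)NCCC[C@H](NC(=O)CN(c1nc(Cl)nc2[nH]cnc12)C1CC1)C(=O)O`: 7.19%
Compound 2 `O=C(OCc1ccccc1)[C@@H]1CCCN1C(=O)CN(c1ncnc2c1ncn2C1CCCCO1)C1CC1`: 7.85%
Compound 3 `O=C(O)CC[C@H](NC(=O)CN(c1nc(Cl)nc2[nH]cnc12)C1CC1)C(=O)O`: 29.5%

In a functional assay on the whole organism (Tail, strain ICR) with Mus musculus as the target, in the tail flick test, with a stated time of 150 min, at a dose of 25 umol/kg by the oral route (on this read-out lower numbers stand for a weaker effect and higher numbers for a stronger effect at the one dose given), compound 3 gives the highest of the three numbers, standing beyond the scatter above compound 2 and above compound 1. Compound 4 `O=C(O)C[C@H](NC(=O)CN(c1nc(Cl)nc2[nH]cnc12)C1CC1)C(=O)O` differs from compound 3 by carboxy in place of carboxymethyl on a saturated chain carbon, two bonds along the chain from an amide-type nitrogen and a carbonyl carbon. Among the compounds with values here, no measured pair shows this exact change. Within the data shown here, the only measured step, a number 22.3 percentage points higher from compound 1 to compound 3 (beyond the scatter), alters the same side chain but in a different way, so it offers little guidance here. Without a matching precedent, the step is expected to stay close to the scatter, in either direction. Compound 4 is therefore estimated at 25%, within 10% to 40%, implying a step of a number 4.5 percentage points lower from compound 3 to compound 4 (within the scatter) that is expected to be small.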

Compound 4, a percentage reported as activity, at one dose (the size of the read-out at that dose, not a potency): 11.6%
For compound 4 the middle estimate is 13.4 percentage points above the measured one; low and high end bracket the measured number.
By their numbers in this assay, from the lowest: compounds 1, 2 and 4 (each within the scatter of the next); then compound 3.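

Shortening carboxymethyl to carboxy on this saturated chain carbon is not a neutral change: it gives a number 17.9 percentage points lower from compound 3 to compound 4 (beyond the scatter) and so shows that the length of the acid side chain matters here. With a number 4.4 percentage points higher from compound 1 to compound 4 (within the scatter) as the companion step, the edge of compound 3 over compound 1 is not shared by compound 4, so carrying a carboxylic acid on this chain is not enough by itself. No measurement on hand accounts for this.

As far as these compounds go, whether a longer chain such as 3-carboxypropyl would go beyond compound 3 stays open. So does whether a primary amide in place of the side-chain carboxylic acid would keep the effect.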